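The source may report more compounds than this note shows. Statements on the series, on what has been measured and on what is new or still open speak of the compounds shown alone.

Measured compounds:
Compound 1 `CN1CCN(c2ccc(Nc3ncc4nc(Nc5ccc(F)cc5)n([C@@H]5CCN(C(=O)CO)C5)c4n3)cc2)CC1` gives "not determined" (no result reported) in a functional assay on A549 cells (Homo sapiens) for antiproliferative activity, read by MTT assay, with a stated time of 72 h; a lower number here means a stronger inhibitor, a higher number a weaker inhibitor.
Compound 2 `CN1CCN(c2ccc(Nc3ncc4nc(Nc5ccc(F)cc5)n([C@H]5CCCN(C(=O)CO)C5)c4n3)cc2)CC1` gives 830 nM in this assay.
Compound 3 `CN1CCN(c2ccc(Nc3ncc4nc(Nc5ccc(F)cc5)n([C@H]5CCNC5)c4n3)cc2)CC1` gives "not determined" (no result reported) in this assay.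

Compound 1 stands without a number: no result was reported for it in this assay, and compound 3 is in the same position. The only figure in the set is that of compound 2, which in this assay gives 830 nM; it shares the core of compound 1 but carries a six-membered rather than a five-membered saturated ring. Compound 4 `CN1CCN(c2ccc(Nc3ncc4nc(Nc5ccc(F)cc5)n([C@@H]5CCN(S(=O)(=O)C6CC6)C5)c4n3)cc2)CC1` is the next step from compound 1. The change is cyclopropylsulfonyl in place of (hydroxymethyl)carbonyl on an amine nitrogen in a ring. Within the data shown here, no step between two measured compounds is available to calibrate this swap, so the writer expects, at most, a step within the usual scatter in this assay, in either direction, and leans on compound 2 as the nearest anchor. The estimate for compound 4 in this assay is 700 nM, expected to fall between 200 nM and 2500 nM.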

Compound 4, half-maximal inhibitory concentration: > 10000 nM
Compound 4: only a limit was reported; the forecaster's own chance of this, stated with the estimate: 5%; middle value at least 14-fold (1.15 log units) from the limit.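

Compound 4 stands as a limit and not a number in this assay: the limit of > 10000 nM in this assay, at which 1 of the 4 values shown sits. Compared with the only figure available, the record shows an at least 12-fold higher number from compound 2 to compound 4 (1.08 log units; beyond the scatter), with 1-(cyclopropylsulfonyl)pyrrolidin-3-yl in place of 1-((hydroxymethyl)carbonyl)piperidin-3-yl on an aromatic nitrogen, the first sign in these compounds that a change at this position can cost much of the antiproliferative activity. That step changes the ring size and the group on the ring nitrogen together, and the direct comparison of compound 4 with compound 1 cannot be read.

Going by these compounds, it remains open how much of the loss belongs to the ring and how much to the group on its nitrogen. On these data alone, it is also open whether the sulfonyl or the cyclopropyl ring matters more, which a methylsulfonyl or a cyclopropylcarbonyl group on the same nitrogen could separate.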